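Branching the Side Chain of Compound 2

This account rests on a few compounds, and the source may have more. Where it says the series, first, only, none or still open, it means among the compounds named here.

In a functional assay on K562 cells (Homo sapiens) for antiproliferative activity, read by CCK-8 assay, with a stated time of 72 h (a higher number here means a weaker inhibitor of growth, a lower number a stronger inhibitor of growth), compound 1 (`CCCNS(=O)(=O)c1ccc(Nc2ncc3c(n2)N(c2ccn(C)n2)C(CC)C(=O)N3C)cc1`) gives 2260 nM, and compound 2 (`CCCCNS(=O)(=O)c1ccc(Nc2ncc3c(n2)N(C2CCCC2)[C@H](CC)C(=O)N3C)cc1`) gives 412 nM. Compound 2 therefore holds the lower of the two numbers, and the gap between them lies beyond the usual scatter. Compound 3 (`CC[C@@H]1C(=O)N(C)c2cnc(Nc3ccc(S(=O)(=O)NCC(C)C)cc3)nc2N1C1CCCC1`) differs from compound 2 in one place: butyl becomes isobutyl, meaning isopropyl in place of propyl on a saturated chain carbon bound to a sulfonamide nitrogen. The two compounds have the same atoms, joined differently. Within the data shown here, no measured pair shows this kind of change in this assay, so the expectation starts from compound 2 and its 412 nM: little movement, none beyond the scatter, and no firm direction. The expected change is a 1.1-fold higher number from compound 2 to compound 3 (0.04 log units; within the scatter). For compound 3, the estimated value is 450 nM, with a likely range from 200 nM to 1000 nM.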

Compound 3, concentration for 50% growth inhibition: 705 nM
The estimate for compound 3 lay 1.6-fold (0.19 log units) below the measured number; the measured number falls inside the stated range.
By their numbers in this assay, from the lowest: compounds 2 and 3 (each within the scatter of the next); then compound 1.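

Swapping propyl for isopropyl on a saturated chain carbon bound to a sulfonamide nitrogen gives, in this assay, a 1.7-fold higher number from compound 2 to compound 3 (0.23 log units; within the scatter). This is the only comparison shown that isolates this position, since compound 1 and compound 2 differ in more than one place, and it shows that this branching of the chain leaves the growth-inhibition number within the scatter of repeated measurements. No supporting measurement bears on this result.

Going by these compounds, a single branched chain says little about the wider range of groups at this position, so it remains open whether a longer chain such as hexyl, or a chain ending in an amine or a carboxylic acid, would give a similar number. On these data alone, it is also open whether isobutyl and butyl would stay this close in a different cell line.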